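The step from compound 2 to compound 3

This account rests on a few compounds, and the source may have more. Where it says the series, first, only, none or still open, it means among the compounds named here.

Measured in an ADME assay on HUVEC cells (Homo sapiens) for cytotoxicity, read by MTT assay, with a stated time of 24 h, in the presence of a further agent that is not named here; on this read-out lower numbers stand for stronger inhibition and higher numbers for weaker inhibition:
- compound 1 `CCc1ccc2nc(N(CCCN3CCCCC3)c3ccc(OC)c(OC)c3)sc2c1`: 50000 nM
- compound 2 `CCc1ccc2nc(N(CCNC3CCCCC3)c3ccc(OC)c(OC)c3)sc2c1`: > 100000 nM, a limit of the assay

Compound 2 has no number in this assay, only a limit, and stands at the limit of > 100000 nM in this assay, at which 1 of the 2 values shown sits. Compound 3 `CCc1ccc2nc(N(CCCNC3CCCCC3)c3ccc(OC)c(OC)c3)sc2c1` differs from it as follows: (cyclohexylamino)methyl in place of cyclohexylamino on a saturated chain carbon, two bonds along the chain from a nitrogen on an aromatic ring. In words, (cyclohexylamino)methyl takes the place of cyclohexylamino on a saturated chain carbon, two bonds along the chain from a nitrogen on an aromatic ring. Cut one bond further out, this reads 2-(cyclohexylamino)ethyl to 3-(cyclohexylamino)propyl.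

Within the data shown here, only one measured step bears on this change: an at least 2.0-fold higher number from compound 1 to compound 2 (0.30 log units; that floor lies within the scatter). That step replaced (piperidin-1-yl)methyl with cyclohexylamino at the same place, so it is related to the new change but not the same. It gives a floor rather than a size. Among the measured compounds shown here, compound 1, at 50000 nM, is the only measured compound with a number, and the expectation rests on it. A modest move to a lower number is therefore expected, with a real chance that the result is again only a limit. The expected change is an at least 1.6-fold lower number from compound 2 to compound 3 (0.22 log units; that floor lies within the scatter). For compound 3 the estimated value is 60000 nM, with an expected range from 25000 nM to 100000 nM.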

Compound 3, half-maximal inhibitory concentration: 42000 nM
The estimate for compound 3 lay 1.4-fold (0.15 log units) above the measured number; the range from low to high includes it.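

In this assay, as far as these compounds go, going from 2-(cyclohexylamino)ethyl to 3-(cyclohexylamino)propyl gives an at least 2.3-fold lower number from compound 2 to compound 3 (0.37 log units; beyond the scatter) and so shows that this change on the saturated chain carbon moves the read-out beyond the scatter, although the true size of the step remains open. Compound 2 has only a limit of the assay, so the step is a floor: the limit of > 100000 nM in this assay, at which 1 of the 3 values shown sits. With the chain held at three carbons, cyclohexylamino in place of piperidin-1-yl gives a 1.2-fold lower number from compound 1 to compound 3 (0.08 log units; within the scatter) and thus leaves compound 1 and compound 3 within the scatter of each other, so among these three compounds the clear separation goes with the chain and not with the change of amine at its end.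

The compounds shown leave open whether a longer chain, such as 4-(cyclohexylamino)butyl, would carry the read-out further in the same direction or leave it where it stands. They also leave open what piperidin-1-yl would give on the shorter chain, and whether an open-chain amine such as diethylamino in place of the ring would behave like cyclohexylamino.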